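The source may hold more compounds than are shown below. What is called first, only, known or untested is meant among the compounds shown, and "the series" means these compounds.

Measured compounds:
compound 1 `Cc1ccnc(NC(c2ccc([N+](=O)[O-])cc2)c2ccc3cccnc3c2O)c1` — 530 nM
compound 2 `Cc1ccc(C(Nc2ccccn2)c2ccc3cccnc3c2O)cc1` — 460 nM

Notes on the series. Among the measured compounds shown here, in an assay for inhibition of protein disulfide-isomerase (Homo sapiens), with a stated time of 1 h (a lower number here means a stronger inhibitor, a higher number a weaker inhibitor), compound 1 gives 530 nM, the higher of the two numbers measured so far. Compound 2 gives 460 nM in this assay, and the two values lie within the scatter of each other, so no order between compound 1 and compound 2 can be read from them. Compound 2 differs from compound 1 in more than one place, so it gives no single-point reference for any one change.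

Compound 3 `Cc1ccnc(NC(c2cccc(F)c2)c2ccc3cccnc3c2O)c1` is not yet measured. It differs from compound 1 as follows: 3-fluorophenyl in place of 4-nitrophenyl on a saturated chain carbon bound to an aromatic carbon and a nitrogen on an aromatic ring. For the measured compounds named here, no measured pair isolates this change, so nothing in the data fixes its direction or size. The expectation is a step in this assay of modest size in either direction, most likely not clearly beyond the scatter, and the estimate for the step is a 1.1-fold higher number from compound 1 to compound 3 (0.05 log units; within the scatter). Compound 3 is therefore expected to give about 600 nM in this assay, with a range from 250 nM to 1500 nM.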

Compound 3, half-maximal inhibitory concentration: 350 nM
Compound 3: the middle estimate sits 1.7-fold (0.23 log units) above what was measured; low and high end bracket the measured number.
By their numbers in this assay, from the lowest: compounds 3, 2 and 1 (each within the scatter of the next).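

Among the compounds shown here, this pair is the first to isolate a single position: on a saturated chain carbon bound to an aromatic carbon and a nitrogen on an aromatic ring, 3-fluorophenyl replaces 4-nitrophenyl, and this assay gives a 1.5-fold lower number from compound 1 to compound 3 (0.18 log units; within the scatter) for the exchange. The position therefore holds either group without a readable difference in this assay, even though the exchange takes the substituted ring from 9 heavy atoms to 7 and from 2 hydrogen-bond acceptors to 0, so neither the nitro group nor the fluorine can be called necessary or harmful on this evidence. No measurement in hand bears on why the two groups read alike.

For the compounds shown here, compound 2 still has no partner that differs from it in one place, so this pair remains the only single-change reading. Going by these compounds, whether an amine, a carboxylic acid or a longer chain on this ring, or an unsubstituted phenyl at the same carbon, would move the number beyond the scatter stays open.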